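Two aminothiophene ketones and a carboxy analogue

The source may report more compounds than this note shows. Statements on the series, on what has been measured and on what is new or still open speak of the compounds shown alone.

Measured so far:
compound 1 `Nc1sc(-c2ccc(C(=O)O)cc2)cc1C(=O)c1ccccc1` — 51%
compound 2 `COc1ccc(-c2cc(C(=O)c3ccc(Cl)cc3)c(N)s2)cc1` — 51%

Both compounds were tested in an assay on CHO cells for positive allosteric modulation of adenosine receptor A1 (Homo sapiens), read by ERK phosphorylation, tested at 3 uM (on this read-out higher numbers stand for a weaker effect at the one concentration tested and lower numbers for a stronger effect), at the single concentration. In this assay compound 1 gives 51%, and in the same test compound 2 gives 51%. The two figures are level at the digits shown, and the gap between them lies within the usual scatter, so no order between compound 1 and compound 2 can be drawn from these numbers. Within the data shown here, no step between two measured compounds differing in a single place is available in this set.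

The next compound, compound 3 `Nc1sc(-c2ccc(C(=O)O)cc2)cc1C(=O)c1ccc(Cl)cc1`, is not yet measured. It differs from compound 2 by carboxy in place of methoxy on an aromatic carbon. The same carboxy group is already present on compound 1, which sits at the same level as compound 2. Among the measured compounds shown here, with two measured compounds at one value and no single-place step in hand, the expectation for compound 3 is a step of no change at the digits printed from compound 2 to compound 3 (within the scatter) in this assay, no change beyond the scatter. Compound 3 is therefore estimated at 51%, within 36% to 66%, pending the measurement.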

Compound 3, a percentage reported as activity, at one concentration (the size of the read-out at that concentration, not a potency): 27%
Beside the measured number, compound 3's estimate is 24 percentage points above it; the measured number lies below the stated range.
By their numbers in this assay, from the lowest: compound 3; then compounds 1 and 2 (each within the scatter of the next).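

In this assay the carboxy group on the aromatic carbon, para to a large group, is not interchangeable with methoxy when chloro is present on the other aromatic ring, as the step (a number 24 percentage points lower from compound 2 to compound 3 (beyond the scatter)) shows. The chloro group also counts when carboxy is held fixed, as the step (a number 24 percentage points lower from compound 1 to compound 3 (beyond the scatter)) shows, so neither place is silent in this small set. The level figures of compound 1 and compound 2 therefore hid two single-place changes, each of which moves the number toward a stronger effect at the one concentration tested, and nothing in the data gives a reason for either step.

The compounds shown leave open whether chloro in place of hydrogen gives a similar step when methoxy is the group on the other ring, and so whether the two changes depend on each other. Also open, on these data alone, are how a methyl ester, a carboxamide or a tetrazole would read in place of carboxy, how fluoro or bromo would read in place of chloro, and how compound 3 would rank across a range of concentrations.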